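Same amine swap on a core that sits at the limit

The source may report more compounds than this note shows. Statements on the series, on what has been measured and on what is new or still open speak of the compounds shown alone.

Three compounds have been measured in a functional assay on EC9706 cells (Homo sapiens) for cytotoxicity, read by MTT assay, with a stated time of 72 h; a lower number here means a stronger inhibitor, a higher number a weaker inhibitor:

Compound 1 `CC(C)NC(=O)N1CCN(C(=S)SCc2cn(Cc3ccccc3F)nn2)CC1`: 20800 nM
Compound 2 `CCN(C)C(=O)N1CCN(C(=S)SCc2cn(Cc3ccccc3F)nn2)CC1`: 15600 nM
Compound 3 `COc1cc(Cn2cc(CSC(=S)N3CCN(C(=O)NC(C)C)CC3)nn2)cc(OC)c1OC`: > 128000 nM, which is a limit of this assay and not a number.

Compound 1 and compound 2 share one core and differ only in the change (ethyl(methyl)amino in place of isopropylamino on a carbonyl carbon). That change gave a 1.3-fold lower number from compound 1 to compound 2 (0.12 log units; within the scatter), so the two values are not told apart here. Compound 3 carries a different core; the difference between the two cores is not broken down here. In this assay compound 3 reached only (the limit of > 128000 nM in this assay, at which 1 of the 3 values shown sits).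

Compound 4 `CCN(C)C(=O)N1CCN(C(=S)SCc2cn(Cc3cc(OC)c(OC)c(OC)c3)nn2)CC1` is built from compound 3 by the change (ethyl(methyl)amino in place of isopropylamino on a carbonyl carbon), the same change as between compound 1 and compound 2, with the same surroundings at the place of change. Since that change gave a 1.3-fold lower number from compound 1 to compound 2 (0.12 log units; within the scatter) on the core of compound 1, a step that the limit leaves unreadable from compound 3 to compound 4 is expected here, and the value of compound 4 is estimated at 150000 nM, between 60000 nM and 400000 nM, most likely again only a limit.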

Compound 4, half-maximal inhibitory concentration: > 128000 nM
Compound 4: only a limit was reported; the forecaster's own chance of this, stated with the estimate: 70%; the middle value does not contradict the limit.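

In this assay compound 3 gives > 128000 nM, which is a limit and not a number. Compound 4 gives > 128000 nM, also a limit, so no step can be read between compound 3 and compound 4. The compounds shown leave open whether ethyl(methyl)amino in place of isopropylamino shifts the number at all on the core of compound 3.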